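Methyl in Place of Hydrogen on an Aromatic Oxygen

A few compounds are considered here, and "the series" means these few. Any claim that something is new, unique, unknown or untested is made for them only; others in the source may bear on it.

Compound 1 `O=C(NCc1ccco1)c1cc(S(=O)(=O)N2CCCCC2)cc(O)c1O` was examined in an ADME assay on NCI-H630 cells (Homo sapiens) for cytotoxicity, read by MTT assay, with a stated time of 72 h (a lower number here means that less compound is tolerated, a higher number that more compound is tolerated), where compound 1 gives 33000 nM. Compound 2 `O=C(NCc1ccc(C(F)(F)F)cc1)c1cc(S(=O)(=O)N2CCCCC2)cc(O)c1O` gives 31000 nM in this assay; the two numbers sit within the usual scatter of each other, as the step of a 1.1-fold lower number from compound 1 to compound 2 (0.03 log units; within the scatter) shows. Compound 3 `O=C(NCc1cccs1)c1cc(S(=O)(=O)N2CCCCC2)cc(O)c1O` reaches only a limit of the assay, > 40000 nM. The steps of an at least 1.2-fold higher number from compound 1 to compound 3 (0.08 log units; that floor lies within the scatter) and an at least 1.2-fold higher number from compound 2 to compound 3 (0.11 log units; that floor lies within the scatter) likewise stay within the scatter. Every one of these changes sits on the saturated chain carbon bound to the amide-type nitrogen, and none touches the hydroxy groups of the shared core.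

Compound 4 `COc1cc(S(=O)(=O)N2CCCCC2)cc(C(=O)NCc2ccco2)c1O` differs from compound 1 by methyl in place of hydrogen on an oxygen on an aromatic ring. Going by the values given here, no measured step concerns this oxygen, so the three steps offer no direct guide; they show only that changes at the amide side did not move the number beyond the scatter. Compound 4 is therefore expected to show a step of no change at the digits printed from compound 1 to compound 4 (within the scatter) that stays inside the scatter. The estimate for compound 4 in this assay is 33000 nM, ranging from 15000 nM to 70000 nM.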

Compound 4, half-maximal cytotoxic concentration: > 25000 nM
Compound 4: no number, only a limit (the forecaster's own chance of this, stated with the estimate: 30%); the middle value is on the limit's open side.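

In this assay compound 4 gives only a limit, > 25000 nM. The step from compound 1 to compound 4 therefore cannot be read. The compounds shown leave open whether methyl in place of hydrogen on this aromatic oxygen shifts the number at all, and in which direction.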